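Aryl in place of benzyl on the ring nitrogen

The source may report more compounds than this note shows. Statements on the series, on what has been measured and on what is new or still open speak of the compounds shown alone.

Measured compounds:
compound 1 `CCOC(=O)CN(Cc1ccccc1)c1nc(NCc2cccc(OC)c2)ncc1[N+](=O)[O-]` — 33600 nM
compound 2 `COC(=O)CN(C)c1nc(NCc2ccccc2)ncc1[N+](=O)[O-]` — > 100000 nM
compound 3 `CCOC(=O)CNc1nc(Nc2ccc(Cl)cc2)ncc1[N+](=O)[O-]` — > 100000 nM

In a functional assay on HepG2 cells (Homo sapiens) for antiproliferative activity, read by MTT assay, with a stated time of 48 h (on this read-out lower numbers stand for stronger inhibition and higher numbers for weaker inhibition), compound 1 gives 33600 nM. Compound 2 reaches only the limit of this assay, > 100000 nM. Compound 3 also stops at the limit, > 100000 nM. Going by the values given here, compound 1 therefore holds the only number among the three; the rest is the limit of > 100000 nM in this assay, at which 2 of the 3 values shown sit. Among the compounds with values here, no two measured compounds differ in a single place, so no measured step can be read off.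

Compound 4 `CCOC(=O)CN(Cc1ccccc1)c1nc(Nc2cccc(OC)c2)ncc1[N+](=O)[O-]` is still to be measured. It differs from compound 1 in one place: 3-methoxyphenyl in place of 3-methoxybenzyl on a nitrogen on an aromatic ring. Compound 3 carries an aryl group directly on the same kind of ring nitrogen and sits at the limit, but it differs from compound 1 in further places as well, so its value cannot be taken as a clean guide for this change. The step from compound 1 to compound 4 is expected to be a 1.8-fold higher number from compound 1 to compound 4 (0.25 log units; within the scatter), a small move toward weaker inhibition that may not clear the usual scatter. Compound 4 is accordingly estimated at 60000 nM, with a range from 18000 nM to 200000 nM.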

Compound 4, half-maximal inhibitory concentration: 27600 nM
Compound 4: middle estimate off by 2.2-fold (0.34 log units), on the high side, and the stated range covers the measured number.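

Going by these compounds alone, the first single-place step reads a 1.2-fold lower number from compound 1 to compound 4 (0.09 log units; within the scatter), so on this nitrogen on an aromatic ring, 3-methoxyphenyl and 3-methoxybenzyl cannot be told apart in this assay. Compound 4 gives 27600 nM, which shows that an aryl group carried directly on this nitrogen can still give a number rather than a limit. Compound 3 could not show this, as it differs from compound 1 in further places, and the swap from (3-methoxybenzyl)amino to (3-methoxyphenyl)amino now stands as a change that leaves the read-out within the scatter in the setting of compound 1.

Going by these compounds, the effect of the benzyl group shared by compound 1 and compound 4 cannot be read from any single-place step, and the series still rests on few numbers: the limit of > 100000 nM in this assay, at which 2 of the 4 values shown sit. Also open is how the read-out would respond to a carboxylic acid or an amide in place of the ethyl ester, or to an amine in place of the nitro group on the shared core.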